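A few compounds are considered here, and "the series" means these few. Any claim that something is new, unique, unknown or untested is made for them only; others in the source may bear on it.

Measured so far in an assay on isolated protein for inhibition of histone deacetylase 4 (Homo sapiens), with a stated time of 1 h; on this read-out higher numbers stand for weaker inhibition and lower numbers for stronger inhibition:
compound 1, `O=C(COc1ccc2cc(/C=C3/SC(=O)NC3=O)ccc2c1)Nc1ccc(F)cc1F`: 3900 nM
compound 2, `O=C(COc1ccc2cc(/C=C3/SC(=O)NC3=O)ccc2c1)Nc1cc(Cl)cc(C(F)(F)F)c1`: 4000 nM
compound 3, `O=C(COc1ccc2cc(/C=C3/SC(=O)NC3=O)ccc2c1)Nc1ccc(Br)c(Br)c1`: 4900 nM

The three values fall together: the steps of a 1.0-fold higher number from compound 1 to compound 2 (0.01 log units; within the scatter), a 1.3-fold higher number from compound 1 to compound 3 (0.10 log units; within the scatter) and a 1.2-fold higher number from compound 2 to compound 3 (0.09 log units; within the scatter) all stay within the scatter, so compound 3 is not set apart from compound 1 or compound 2 on this read-out.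

Compound 4, `O=C(COc1ccc2cc(/C=C3/SC(=O)NC3=O)ccc2c1)Nc1ccc(Br)cc1`, differs from compound 3 by hydrogen in place of bromo on an aromatic carbon, ortho to a bromo group and meta to a large group, so that 3,4-dibromophenyl becomes 4-bromophenyl on the amide-type nitrogen. Every measured step in the series swaps the substitution pattern of this aryl ring, and none moved the number beyond the scatter. The expected step of a 1.1-fold lower number from compound 3 to compound 4 (0.04 log units; within the scatter) is therefore none beyond the scatter. Compound 4 is estimated at 4500 nM, in the range 2000 nM to 10000 nM.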

Compound 4, half-maximal inhibitory concentration: 2900 nM
Compound 4: middle estimate off by 1.6-fold (0.19 log units), on the high side; the measured number falls inside the stated range.
By their numbers in this assay, from the lowest: compounds 4, 1, 2 and 3 (each within the scatter of the next).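

In this assay, hydrogen in place of bromo, ortho to a bromo group, turns 3,4-dibromophenyl into 4-bromophenyl and gives a step within the scatter (a 1.7-fold lower number from compound 3 to compound 4 (0.23 log units; within the scatter)). The single bromo also stays within the scatter of the other aryl patterns (a 1.4-fold lower number from compound 2 to compound 4 (0.14 log units; within the scatter)) and (a 1.3-fold lower number from compound 1 to compound 4 (0.13 log units; within the scatter)), so this ring has not yet separated any compounds. No measured evidence bears on these steps.

Open, going by these compounds, is whether the ring without any bromo, or one bearing an amine or a carboxylic acid, would step beyond the scatter.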